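The compounds below may be only part of what the source reports. "The series", "measured", "known", "first", "only" and "open" are said of these compounds alone.

Of the compounds shown here, three built on one shared core have been tested so far. Compound 1 `Cc1nc2ccc(Br)cc2c(=O)n1NCc1nnc(N2C(=O)CSC2c2ccc(O)cc2)s1` carries a bromo group on the core, compound 2 `Cc1nc2ccccc2c(=O)n1NCc1nnc(/N=C/c2ccc(N(C)C)cc2)s1` bears a different side arm, and compound 3 `Cc1nc2ccccc2c(=O)n1NCc1nnc(N2C(=O)CSC2c2ccc(O)cc2)s1` matches compound 1 except that the bromo group is gone. In a functional assay on the whole organism (strain albino) with Rattus norvegicus as the target, in the maximal electroshock model, with a stated time of 1 h, at a dose of 30 mg/kg by the intraperitoneal route (on this read-out lower numbers stand for less inhibition and higher numbers for more inhibition at the one dose given (going by the name of the read-out)), compound 1 gives 60%, compound 2 gives 50% and compound 3 gives 60%. Among the measured compounds shown here, the one step that compares two compounds differing in a single place is no change at the digits printed from compound 1 to compound 3 (within the scatter). On the numbers shown, compound 3 stands level with compound 1, the two together being the highest of the three, and compound 2 lies within the scatter of both.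

Compound 4 `Cc1nc2ccccc2c(=O)n1NCc1nnc(N2C(=O)CSC2c2ccccc2)s1` is the next compound, and it differs from compound 3 by hydrogen in place of hydroxy on an aromatic carbon. For the measured compounds named here, no measured step touches this hydroxy group; the only available step concerns a bromo group elsewhere and showed no change. Without a guide, the expected step of a number 5 percentage points lower from compound 3 to compound 4 (within the scatter) is none beyond the scatter, so compound 4 is estimated at 55%, between 35% and 75%.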

Compound 4, a percentage reported as inhibition, in the whole organism at one dose (the size of the read-out at that dose, not a potency): 60%
Beside the measured number, compound 4's estimate is 5 percentage points below it; the measured number falls inside the stated range.
By their numbers in this assay, from the lowest: compounds 2, 1, 3 and 4 (each within the scatter of the next).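

In this assay, the change from 4-hydroxyphenyl to phenyl gives no change at the digits printed from compound 3 to compound 4 (within the scatter). The earlier step concerned a bromo group on the shared core, whereas this one shows that the six-membered aromatic ring can also lose its hydroxy group, with that group's hydrogen-bond donor and acceptor, and the number at this single dose stays the same. Nothing available explains why the number holds.

From the compounds shown here alone, a single dose gives the size of the effect at that dose and not a potency, so any difference that would show only at other doses remains open. Also open, going by these compounds, is how this para place responds to other groups, such as a methoxy group, an amine or a carboxylic acid, and whether phenyl behaves the same with the bromo group on the core.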